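Swapping a cyclopropyl for a phenyl at the chain end

The compounds below may be only part of what the source reports. "The series", "measured", "known", "first", "only" and "open" are said of these compounds alone.

Measured so far:
- compound 1, `CNC(=O)[C@@H]1C[C@H](N2CCc3c(ncnc3OCCC3CC3)C2)CN1C(=O)c1ccc(CN)c(OC)c1`, 6 nM
- compound 2, `COc1cc(C(=O)N2C[C@@H](n3cc(C4CC4)nn3)C[C@H]2C(=O)N[C@H]2C[C@@H]2c2ccccc2)ccc1CN`, 960 nM
- compound 3, `CNC(=O)[C@@H]1C[C@H](N2CCc3c(cccc3OCCOC)C2)CN1C(=O)c1ccc(CN)c(OC)c1`, 8 nM

These values come from an assay on isolated protein for inhibition of serine protease 1 (Homo sapiens), read by fluorescence; a higher number here means a weaker inhibitor, a lower number a stronger inhibitor. Compound 1 has the lowest number of the three, but its gap to compound 3 lies within the scatter, so the two cannot be told apart; compound 2 sits far beyond the scatter from both. Compound 4, `CNC(=O)[C@@H]1C[C@H](N2CCc3c(ncnc3OCCc3ccccc3)C2)CN1C(=O)c1ccc(CN)c(OC)c1`, differs from compound 1 in one place: phenyl in place of cyclopropyl on a saturated chain carbon, two bonds along the chain from an oxygen on an aromatic ring. Among the compounds with values here, no measured pair shows this exact change, so its size is open. Compound 3 carries a different chain at the same oxygen and still matches compound 1, which suggests the chain end tolerates variation. The step from compound 1 to compound 4 is expected to be small, perhaps slightly toward a higher number: a 1.7-fold higher number from compound 1 to compound 4 (0.22 log units; within the scatter). Compound 4 is estimated at 10 nM in this assay, within a range from 3 nM to 40 nM.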

Compound 4, half-maximal inhibitory concentration: 5 nM
Estimate against measurement, compound 4: 2.0-fold (0.30 log units) above, and the stated range covers the measured number.
By their numbers in this assay, from the lowest: compounds 4, 1 and 3 (each within the scatter of the next); then compound 2.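

Measured in this assay the change from cyclopropyl to phenyl on a saturated chain carbon, two bonds along the chain from an oxygen on an aromatic ring, gives a 1.2-fold lower number from compound 1 to compound 4 (0.08 log units; within the scatter) and so leaves the two compounds indistinguishable. This single-change pair shows directly that, on this core, a six-membered aromatic ring at the chain end serves as well as a three-membered carbon ring. No measurement here explains why the number holds.

As far as these compounds go, whether the chain end would also accept an amine or a carboxylic acid remains open. So does the outcome of a longer chain carrying the phenyl.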